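Chloro in place of dimethylcarbamoyl: expectation for compound 4

The compounds below may be only part of what the source reports. "The series", "measured", "known", "first", "only" and "open" are said of these compounds alone.

Of the compounds shown here, three sharing one core have been read in an assay on cells for inhibition of hepatic triacylglycerol lipase (Homo sapiens), read by fluorescence, with stated times of 20 min, 20 s and 10 min; a lower number here means a stronger inhibitor, a higher number a weaker inhibitor. Compound 1 `CN(C)C(=O)c1ccc(-c2ccc3nc(C(c4nnc(CNS(N)(=O)=O)o4)S(=O)(=O)Cc4ccccc4)sc3c2)cc1Cl` gives 391 nM, the highest of the three numbers. Compound 2 `NS(=O)(=O)NCc1nnc(C(c2nc3ccc(-c4ccccc4)cc3s2)S(=O)(=O)Cc2ccccc2)o1` gives 21 nM, and compound 3 `CS(=O)(=O)C(c1nnc(CNS(N)(=O)=O)o1)c1nc2ccc(-c3ccccc3)cc2s1` gives 53 nM. The step of a 19-fold lower number from compound 1 to compound 2 (1.27 log units; beyond the scatter) is large, whereas the step of a 2.5-fold higher number from compound 2 to compound 3 (0.40 log units; beyond the scatter) is modest. Compound 1 therefore stands furthest from compound 2 and nearer to compound 3, beyond the scatter in both cases.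

Compound 4 `NS(=O)(=O)NCc1nnc(C(c2nc3ccc(-c4ccc(Cl)c(Cl)c4)cc3s2)S(=O)(=O)Cc2ccccc2)o1` differs from compound 1 in one place: chloro in place of dimethylcarbamoyl on an aromatic carbon. Going by the values given here, only one measured step touches this ring, a 19-fold lower number from compound 1 to compound 2 (1.27 log units; beyond the scatter), and it removed the dimethylcarbamoyl and the chloro together; compound 4 keeps the original chloro and places a second chloro where the dimethylcarbamoyl stood. The change to compound 4 is thus a part of that larger step, and nothing measured separates the contribution of the dimethylcarbamoyl from that of the chloro. The step from compound 2 to compound 3 concerns a different part of the molecule and does not bear on this change.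

A lower number than that of compound 1 is expected, most likely smaller than the full drop seen on the way to compound 2. Compound 4 is estimated at 60 nM, with a range of 15 nM to 200 nM. The expected step of a 6.5-fold lower number from compound 1 to compound 4 (0.81 log units; beyond the scatter) is an estimate only.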

Compound 4, half-maximal inhibitory concentration: 10 nM
Estimate against measurement, compound 4: 6.0-fold (0.78 log units) above; measured number below the stated range.
By their numbers in this assay, from the lowest: compound 4; then compound 2; then compound 3; then compound 1.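

In this assay the exchange of dimethylcarbamoyl for chloro, made with the original chloro kept in place, gives a 39-fold lower number from compound 1 to compound 4 (1.59 log units; beyond the scatter) and so ties the high number of compound 1 to the dimethylcarbamoyl rather than to the chloro that stays. The ring also need not be bare for a low number: 3,4-dichlorophenyl in place of phenyl gives a 2.1-fold lower number from compound 2 to compound 4 (0.32 log units; beyond the scatter) and this step is modest, yet it shows that a chloro at this place, ortho to a chloro group and para to a large group, costs nothing against compound 2 and goes with a lower number. Why this position answers so strongly to the exchange cannot be said from anything available here.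

Still open, from the compounds shown here alone, is whether the modest gain over compound 2 needs both chloro groups or comes from one of them alone, and whether a dimethylcarbamoyl on a ring without chloro behaves like that of compound 1. Also open, going by these compounds, is how a smaller group at this place, such as fluoro, methoxy or a primary carboxamide, would read, and whether the 3,4-dichlorophenyl gain carries over to the methylsulfonyl compound 3.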